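Two measured compounds and a fluoro analogue still to come

This account rests on a few compounds, and the source may have more. Where it says the series, first, only, none or still open, it means among the compounds named here.

Measured in a functional assay on the whole organism for inhibition, with Rattus norvegicus as the target, read by paw edema, with a stated time of 30 min, at a dose of 80 mg/kg by the oral route; a higher number here means a stronger effect of the compound at the dose given, a lower number a weaker effect:
compound 1 `Clc1ccc(OCC2=NCCO2)cc1` gives 94.1%
compound 2 `Cc1cc(OCC2=NCCO2)ccc1Cl` gives 77.1%

Compound 1 stands highest of the two numbers; its nearest neighbour is compound 2, separated by a number 17 percentage points lower from compound 1 to compound 2 (beyond the scatter), a change that is methyl in place of hydrogen on an aromatic carbon.

Compound 3 `Fc1ccc(OCC2=NCCO2)cc1` is not yet measured in this assay. It differs from compound 1 in one place: fluoro in place of chloro on an aromatic carbon. Among the measured compounds shown here, the single measured step, a number 17 percentage points lower from compound 1 to compound 2 (beyond the scatter), concerns a methyl and not a halogen exchange, so it does not bear on this change; no measured pair sets chloro against fluoro, and the step from compound 1 to compound 3 is therefore unanchored.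

For the measured compounds named here, with no step to rest on, compound 3 is expected to stay near compound 1 with some loss allowed, estimated at 82% (range 55% to 98%). This estimate means an expected a number 12.1 percentage points lower from compound 1 to compound 3 (beyond the scatter).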

Compound 3, a percentage reported as inhibition, in the whole organism at one dose (the size of the read-out at that dose, not a potency): 40.5%
Compound 3: middle estimate off by 41.5 percentage points, on the high side; the measured number lies below the stated range.
By their numbers in this assay, from the lowest: compound 3; then compound 2; then compound 1.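

In this assay, the substituent on the aromatic carbon para to a group of 7 heavy atoms proves sensitive to the identity of the halogen: with fluoro in place of chloro, the series shows a number 53.6 percentage points lower from compound 1 to compound 3 (beyond the scatter), although the heavy-atom count of the two groups is the same. The earlier pair addressed only a methyl in place of hydrogen on an aromatic carbon, whereas this step shows that one halogen cannot be assumed to stand in for another here, and chloro in compound 1 gives the highest read-out of the compounds shown. No available measurement accounts for the size of this step.

The compounds shown leave open how bromo, methoxy or an amine would read at this same position. With only chloro and fluoro compared there, no trend across substituents can be drawn.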